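The source may hold more compounds than are shown below. What is called first, only, known or untested is meant among the compounds shown, and "the series" means these compounds.

Three compounds have numbers in a functional assay on NCI-H460 cells (Homo sapiens) for antiproliferative activity, with a stated time of 48 h; on this read-out higher numbers stand for weaker inhibition of growth and lower numbers for stronger inhibition of growth:
compound 1 `Cc1cc(O)c(C2=NN(c3ccc(S(N)(=O)=O)cc3)C(c3ccccc3O)C2)cc1Cl`, which gives 4480 nM;
compound 2 `Cc1cc(O)c(C2=NN(c3ccc(S(N)(=O)=O)cc3)C(c3ccccc3Cl)C2)cc1Cl`, which gives 4210 nM;
compound 3 `Cc1cc(O)c(C2=NN(c3ccc(S(N)(=O)=O)cc3)C(/C=C/c3ccccc3)C2)cc1Cl`, which gives 17000 nM.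

Compound 3 has the highest of the three numbers; compound 1 is the nearest to it and compound 2 the furthest, both beyond the scatter. Compound 4 `COc1ccc(C2CC(c3cc(Cl)c(C)cc3O)=NN2c2ccc(S(N)(=O)=O)cc2)c(OC)c1OC` differs from compound 3 by 2,3,4-trimethoxyphenyl in place of 2-phenylethenyl on a saturated ring carbon. Within the data shown here, the steps that bear on this place are a 3.8-fold higher number from compound 1 to compound 3 (0.58 log units; beyond the scatter) and a 4.0-fold higher number from compound 2 to compound 3 (0.61 log units; beyond the scatter), each of which put the 2-phenylethenyl group in place of a substituted phenyl and gave a modest rise. Compound 4 reverses that kind of exchange, so a modest fall in this assay is expected, a 3.4-fold lower number from compound 3 to compound 4 (0.53 log units; beyond the scatter). The estimate for compound 4 is 5000 nM, within a range from 2000 nM to 15000 nM.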

Compound 4, concentration for total growth inhibition: 3870 nM
For compound 4 the middle estimate is 1.3-fold (0.11 log units) above the measured one; measured number inside the range.
By their numbers in this assay, from the lowest: compounds 4, 2 and 1 (each within the scatter of the next); then compound 3.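

In this assay, a third substituted phenyl group on this saturated ring carbon, 2,3,4-trimethoxyphenyl, also gives a lower number than 2-phenylethenyl (a 4.4-fold lower number from compound 3 to compound 4 (0.64 log units; beyond the scatter)). It cannot be told apart from 2-chlorophenyl (a 1.1-fold lower number from compound 2 to compound 4 (0.04 log units; within the scatter)) or 2-hydroxyphenyl (a 1.2-fold lower number from compound 1 to compound 4 (0.06 log units; within the scatter)), so the methoxy groups bring no change beyond the scatter among these compounds. No evidence is available to explain this result. The compounds shown leave open how a phenyl group without substituents, a cyclohexyl group or an aminomethyl group would read out at this carbon.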